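The compounds below may be only part of what the source reports. "The series", "measured", "known", "first", "only" and "open" are said of these compounds alone.

Measured in an ADME assay on HEK-293T cells (Homo sapiens) for cytotoxicity, read by MTT assay, with a stated time of 24 h (a higher number here means that more compound is tolerated, a lower number that less compound is tolerated), so far:

compound 1 `O=C(c1ccccc1)n1c(-c2cn(-c3ccccc3)nc2-c2ccc(F)cc2)nc2ccccc21` — 180000 nM
compound 2 `O=C(c1cccnc1)n1c(-c2cn(-c3ccccc3)nc2-c2ccc(F)cc2)nc2ccccc21` — 216000 nM
compound 3 `O=C(c1ccccc1)n1c(-c2cn(-c3ccccc3)nc2-c2ccc(C(F)(F)F)cc2)nc2ccccc21` — 168000 nM

All three numbers in this assay sit close together. The change from compound 1 to compound 2 is pyridin-3-yl in place of phenyl on a carbonyl carbon; it gave a 1.2-fold higher number from compound 1 to compound 2 (0.08 log units; within the scatter). The cores of compound 1 and compound 3 differ by trifluoromethyl in place of fluoro on an aromatic carbon, and that pair gave a 1.1-fold lower number from compound 1 to compound 3 (0.03 log units; within the scatter). Compound 2 and compound 3 are not a single-change pair; their two values differ only within the scatter.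

Compound 4 `O=C(c1cccnc1)n1c(-c2cn(-c3ccccc3)nc2-c2ccc(C(F)(F)F)cc2)nc2ccccc21` remains to be measured. It differs from compound 3 by pyridin-3-yl in place of phenyl on a carbonyl carbon. The place line is the same word for word as for compound 1 to compound 2, so this is the same change, made a second time on the core of compound 3.

The step in this assay is expected to be a 1.2-fold higher number from compound 3 to compound 4 (0.08 log units; within the scatter), set beside the earlier 1.2-fold higher number from compound 1 to compound 2 (0.08 log units; within the scatter); this rests on compound 3 at 168000 nM. Compound 4 is accordingly estimated at 200000 nM, with an expected range from 110000 nM to 380000 nM.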

Compound 4, half-maximal cytotoxic concentration: 158000 nM
Beside the measured number, compound 4's estimate is 1.3-fold (0.10 log units) above it; the measured number falls inside the stated range.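

In this assay, pyridin-3-yl in place of phenyl on a carbonyl carbon gave a 1.1-fold lower number from compound 3 to compound 4 (0.03 log units; within the scatter), and this step agrees with the earlier one on the other core: the same change on two cores in this assay, a 1.2-fold higher number (0.08 log units; within the scatter) from compound 1 to compound 2 and a 1.1-fold lower number (0.03 log units; within the scatter) from compound 3 to compound 4, 1.3-fold (0.11 log units) apart, within the scatter of two such steps

Trifluoromethyl in place of fluoro on an aromatic carbon, now read with the pyridin-3-yl carbonyl present, gave a 1.4-fold lower number from compound 2 to compound 4 (0.14 log units; within the scatter), and this step also agrees with its earlier counterpart: the same change on two cores in this assay, a 1.1-fold lower number (0.03 log units; within the scatter) from compound 1 to compound 3 and a 1.4-fold lower number (0.14 log units; within the scatter) from compound 2 to compound 4, 1.3-fold (0.11 log units) apart, within the scatter of two such steps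

Both changes therefore carry across these two cores without any step leaving the scatter, but steps this small fix neither a direction nor a real effect for either change, and the agreement covers only these four compounds.

Going by these compounds, it remains open whether the numbers stay this close with a different kind of group in place of the phenyl or pyridin-3-yl on the carbonyl carbon, such as an amine or a carboxylic acid. The same question holds for a longer alkyl chain in place of the fluoro or trifluoromethyl on the aromatic carbon.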